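The compounds below may be only part of what the source reports. "The series", "measured", "known", "first", "only" and "open" are said of these compounds alone.

Working notes on the series. The shared core appears in compound 1 `COc1ccc(CN(C(C)=O)c2cc(OC)c(OC)c(OC)c2)cc1O`, compound 2 `COc1cc(NCc2ccccc2)cc(OC)c1OC` and compound 3 `C/C=C/C(=O)N(Cc1ccc(OC)c(Cl)c1)c1cc(OC)c(OC)c(OC)c1`. In a functional assay on MGC-803 cells (Homo sapiens) for inhibition, read by MTT assay, with a stated time of 48 h (on this read-out higher numbers stand for weaker inhibition and lower numbers for stronger inhibition), compound 1 gives 79 nM, the lowest of the two numbers shown. Compound 3 gives 7100 nM in this assay, a gap from compound 1 that lies beyond the scatter; these two compounds differ in more than one place, so their values show only that the pairing of the longer unsaturated acyl chain with the altered benzyl group sits far weaker. Compound 2 gives > 80000 nM in this assay, which is a limit of the assay and not a number. Compound 2 therefore sits at the limit of > 80000 nM in this assay, at which 1 of the 3 values shown sits.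

Compound 4 `CC/C=C/C(=O)N(Cc1ccc(OC)c(O)c1)c1cc(OC)c(OC)c(OC)c1` is compound 1 with a single change, (but-1-en-1-yl in place of methyl on a carbonyl carbon). Among the compounds with values here, no pair differing in one place has been measured, so the size of this step is not known from the data. Since the acetyl compound 1 gives 79 nM while the unsaturated acyl compound 3 gives 7100 nM, a step toward weaker inhibition, beyond the scatter, is expected from compound 1 to compound 4, estimated as a 7.6-fold higher number from compound 1 to compound 4 (0.88 log units; beyond the scatter). Compound 4 is therefore expected to give about 600 nM in this assay, within 120 nM to 3000 nM.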

Compound 4, half-maximal inhibitory concentration: 58 nM
Compound 4: middle estimate off by 10-fold (1.01 log units), on the high side; measured number below the stated range.
By their numbers in this assay, from the lowest: compounds 4 and 1 (each within the scatter of the next); then compound 3. At a limit, above all of these: compound 2.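

Within the data shown here, this is the first pair that differs in one place, and it isolates the group on the carbonyl carbon whose other neighbour is the amide-type nitrogen: with but-1-en-1-yl in place of methyl, this assay gives a 1.4-fold lower number from compound 1 to compound 4 (0.13 log units; within the scatter). The earlier compounds shown here all differed in more than one place and could not separate the acyl group from the rest of the structure, whereas this pair shows that, with the rest of compound 1 unchanged, going from the acetyl group to the (but-1-en-1-yl)carbonyl group leaves the value within the scatter, despite the longer chain and the added double bond outside aromatic rings. Nothing measured in the series gives a reason for this outcome.

The compounds shown leave open how a saturated butyl chain, a longer chain, or a chain ending in an amine or a carboxylic acid would read at this carbonyl carbon in this assay. Among these compounds, they also leave open how far a change to the benzyl group alone would shift the value, as no pair isolating that group is available.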